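The source may hold more compounds than are shown below. What is called first, only, known or untested is meant among the compounds shown, and "the series" means these compounds.

Measured so far:
compound 1, `CC(C)(C)OC(=O)NCCCCNc1cc(/C=C/c2ccccc2)nc2ccccc12`: 3700 nM in an ADME assay on J774 cells (Mus musculus) for cytotoxicity, read by MTT assay, with a stated time of 48 h; on this read-out lower numbers stand for stronger inhibition and higher numbers for weaker inhibition
compound 2, `CN1CCN(CC(=O)NCCNc2cc(/C=C/c3ccccc3)nc3ccccc23)CC1`: 34000 nM
compound 3, `O=C(CNc1ccccc1)NCCNc1cc(/C=C/c2ccccc2)nc2ccccc12`: 7800 nM

Among these three, compound 1 gives the lowest number, and its gaps to compound 3 and to compound 2 both lie beyond the scatter. Compound 4, `CCOCC(=O)NCCNc1cc(/C=C/c2ccccc2)nc2ccccc12`, differs from compound 1 in one place: ((ethoxymethyl)carbonyl)amino in place of 2-((tert-butoxycarbonyl)amino)ethyl on a saturated chain carbon, two bonds along the chain from a nitrogen on an aromatic ring. For the measured compounds named here, only one measured step bears on this, and only loosely: a 4.4-fold lower number from compound 2 to compound 3 (0.64 log units; beyond the scatter), which shows that exchanging the group at the far end of such a chain can shift the number a modest amount. Because compound 2 gives 34000 nM and compound 3 gives 7800 nM, both with a carbonyl at the chain end, a step toward a higher number is expected, estimated as a 2.4-fold higher number from compound 1 to compound 4 (0.39 log units; beyond the scatter). Compound 4 is thus estimated at 9000 nM, between 3500 nM and 25000 nM.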

Compound 4, half-maximal inhibitory concentration: 22200 nM
Beside the measured number, compound 4's estimate is 2.5-fold (0.39 log units) below it; low and high end bracket the measured number.
By their numbers in this assay, from the lowest: compound 1; then compound 3; then compounds 4 and 2 (each within the scatter of the next).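

In this assay this change at the chain carbon produces a clear shift (a 6.0-fold higher number from compound 1 to compound 4 (0.78 log units; beyond the scatter)), although neither group has a ring or a net charge. With the carbonyl kept, ethoxy separates from anilino (a 2.8-fold higher number from compound 3 to compound 4 (0.45 log units; beyond the scatter)) but not from 4-methylpiperazin-1-yl (a 1.5-fold lower number from compound 2 to compound 4 (0.19 log units; within the scatter)). No measurement shown here explains these shifts. Going by these compounds, the entering and leaving groups differ throughout, so which part of them matters remains open. So does the reading for a primary amine or a carboxylic acid in place of ethoxy.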